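This account rests on a few compounds, and the source may have more. Where it says the series, first, only, none or still open, it means among the compounds named here.

Measured so far in a functional assay on PC-3 cells (Homo sapiens) for cytotoxicity, read by MTT assay, with a stated time of 48 h; a higher number here means a weaker inhibitor, a lower number a stronger inhibitor: compound 1 `COc1cc(-c2nnc3n2NC(c2ccco2)C(C(=O)c2ccccc2C)S3)cc(OC)c1OC` gives 88400 nM; compound 2 `COc1cc(-c2nnc3n2NC(c2ccco2)C(C(=O)c2ccc(Br)cc2)S3)cc(OC)c1OC` gives 36400 nM; compound 3 `COc1cc(-c2nnc3n2NC(c2ccco2)C(C(=O)c2ccc(Cl)cc2)S3)cc(OC)c1OC` gives 67800 nM.

Compound 3 holds the second highest of the three numbers. Its nearest neighbour is compound 1, with a 1.3-fold lower number from compound 1 to compound 3 (0.12 log units; within the scatter); its furthest is compound 2, with a 1.9-fold higher number from compound 2 to compound 3 (0.27 log units; within the scatter). Both gaps lie within the scatter, so no order among these three can be read from the numbers.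

Compound 4 `COc1cc(-c2nnc3n2NC(c2ccco2)C(C(=O)c2ccc(F)cc2)S3)cc(OC)c1OC` differs from compound 3 in one place: fluoro in place of chloro on an aromatic carbon. The step that bears most directly on this change is the halogen swap at the same place, a 1.9-fold higher number from compound 2 to compound 3 (0.27 log units; within the scatter), which stayed within the scatter. Going by the values given here, the only step beyond the scatter so far, a 2.4-fold lower number from compound 1 to compound 2 (0.39 log units; beyond the scatter), exchanges a whole ring substituent and does not speak to a halogen-for-halogen swap. On that basis no step beyond the scatter is expected in this assay, with at most a small drift toward a higher number.

The expected result for compound 4 is 80000 nM, within a range of 35000 nM to 180000 nM, which amounts to an expected 1.2-fold higher number from compound 3 to compound 4 (0.07 log units; within the scatter).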

Compound 4, half-maximal inhibitory concentration: 27700 nM
The estimate for compound 4 lay 2.9-fold (0.46 log units) above the measured number, outside the stated range (below it).
By their numbers in this assay, from the lowest: compounds 4, 2, 3 and 1 (each within the scatter of the next, the first and the last beyond it).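

In this assay, a swap between halogens at this aromatic carbon, para to a large group, now produces a step beyond the scatter: a 2.4-fold lower number from compound 3 to compound 4 (0.39 log units; beyond the scatter). This does not give a simple order by halogen, as fluoro and bromo do not separate, a 1.3-fold lower number from compound 2 to compound 4 (0.12 log units; within the scatter), and chloro stays within the scatter of bromo, a 1.9-fold higher number from compound 2 to compound 3 (0.27 log units; within the scatter). Replacing 2-methylphenyl with 4-fluorophenyl gives a 3.2-fold lower number from compound 1 to compound 4 (0.50 log units; beyond the scatter), in line with the 4-bromophenyl step, a 2.4-fold lower number from compound 1 to compound 2 (0.39 log units; beyond the scatter), while the 4-chlorophenyl step goes against that pattern, a 1.3-fold lower number from compound 1 to compound 3 (0.12 log units; within the scatter), and no available data account for the fluoro and chloro gap.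

As far as these compounds go, whether the gap would persist on repeat measurement remains open, since it only just passes the scatter. Also open, from the compounds shown here alone, is how a methoxy group, an amine or a carboxylic acid would read at this place.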